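The source may hold more compounds than are shown below. What is called first, only, known or untested is meant among the compounds shown, and "the series" means these compounds.

Measured compounds in an assay on HEK cells for antagonist activity at transient receptor potential cation channel subfamily V member 1 (Homo sapiens), read by FLIPR; a lower number here means a stronger inhibitor, a higher number a weaker inhibitor:
Compound 1 `O=C(NCc1ccc(C(F)(F)F)nc1N1CCC(Cc2ccccc2)CC1)Nc1cccc2[nH]c(=O)ccc12`, 1.59 nM
Compound 2 `CCCN(CCC)c1nc(C(F)(F)F)ccc1CNC(=O)Nc1cccc2[nH]c(=O)ccc12`, 5.21 nM
Compound 3 `CCCCOc1nc(C(F)(F)F)ccc1CNC(=O)Nc1cccc2[nH]c(=O)ccc12`, 4 nM

Compound 2 gives the largest of the three numbers in this assay, though compound 3 sits within the scatter of it, while compound 1 lies beyond the scatter on the lower side. Compound 4 `CC(C)COc1nc(C(F)(F)F)ccc1CNC(=O)Nc1cccc2[nH]c(=O)ccc12` is not yet measured; it differs from compound 2 in one place: isobutoxy in place of dipropylamino on an aromatic carbon. Within the data shown here, the one measured step that bears on this is a 1.3-fold lower number from compound 2 to compound 3 (0.11 log units; within the scatter), where a straight alkoxy group took the same position. Isobutoxy is a branched relative of butoxy, so no step beyond the scatter is expected from compound 2 to compound 4 in this assay, with a 1.3-fold lower number from compound 2 to compound 4 (0.11 log units; within the scatter) as the estimate. Compound 4 is therefore expected at 4 nM, in the range 1.5 nM to 12 nM.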

Compound 4, half-maximal inhibitory concentration: 2.6 nM
Compound 4: the middle estimate sits 1.5-fold (0.19 log units) above what was measured; the range from low to high includes it.
By their numbers in this assay, from the lowest: compounds 1, 4, 3 and 2 (each within the scatter of the next, the first and the last beyond it).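

In this assay, replacing dipropylamino with isobutoxy leaves the number within the scatter (a 2.0-fold lower number from compound 2 to compound 4 (0.30 log units; within the scatter)). Branching the alkoxy chain does the same (a 1.5-fold lower number from compound 3 to compound 4 (0.19 log units; within the scatter)), so this position accepts a branched alkoxy group as well as a straight one, and neither change here moves the number beyond the scatter. Nothing available explains this tolerance. Still open, as far as these compounds go, is whether methoxy, a free hydroxyl or a primary amine at this position would stay in the same range, and whether a much longer alkoxy chain would.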